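The compounds below may be only part of what the source reports. "The series", "measured", "known", "first", "only" and "open" are said of these compounds alone.

Measured in an ADME assay on the whole organism (strain CD-1) for metabolic stability, with Mus musculus as the target, at a dose of 3 mg/kg by the intravenous route; on this read-out higher numbers stand for a longer-lived compound and lower numbers for a shorter-lived compound:
- compound 1 `C[C@H](CCCOc1ccccc1CN(C)C(=O)c1ccc(-c2ccco2)cc1)CC(=O)O`: 3.9 h
- compound 2 `CN(Cc1ccccc1OCCC[C@@H]1C[C@H]1C(=O)O)C(=O)c1ccc(-c2ccco2)cc1`: 3.5 h

Going by the values given here, compound 2 stands at 3.5 h, within the scatter of compound 1, and the series has only these two numbers so far. Next is compound 3 `CC(CCOc1ccccc1CN(C)C(=O)c1ccc(-c2ccco2)cc1)CCC(=O)O`, not yet measured in this assay. The change is 3-carboxy-1-methylpropyl in place of (2-carboxycyclopropyl)methyl on a saturated chain carbon, two bonds along the chain from an oxygen on an aromatic ring.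

Among the compounds with values here, one measured step bears on this. It is a 1.1-fold lower number from compound 1 to compound 2 (0.05 log units; within the scatter), which put the 2-carboxycyclopropyl group in place of the open 1-(carboxymethyl)ethyl chain and stayed within the scatter. The present change runs the other way, from the ring back to an open chain. On that single step, no shift beyond the scatter is expected. The step expected is a 1.4-fold lower number from compound 2 to compound 3 (0.15 log units; within the scatter), a small one. Within the data shown here, no measured compound carries the 3-carboxy-1-methylpropyl group, and the range is left wider on the low side. The estimated half-life of compound 3 is 2.5 h, with an expected range from 0.9 h to 4.5 h.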

Compound 3, half-life: 1.7 h
The estimate for compound 3 lay 1.5-fold (0.17 log units) above the measured number; the range from low to high includes it.
By their numbers in this assay, from the lowest: compound 3; then compounds 2 and 1 (each within the scatter of the next).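

This position responds to the shape of the chain in this assay: the step from ring to open chain, a 2.1-fold lower number from compound 2 to compound 3 (0.31 log units; beyond the scatter), lies beyond the scatter, whereas the earlier ring-for-chain step between compound 1 and compound 2 did not. An open chain alone does not go with the lower number, since compound 1 also has one, yet a 2.3-fold lower number from compound 1 to compound 3 (0.36 log units; beyond the scatter), again beyond the scatter, when 3-carboxy-1-methylpropyl replaces 2-(carboxymethyl)propyl at the same place, on a saturated chain carbon two bonds along the chain from an oxygen on an aromatic ring. The series offers no supporting data that would explain why the half-life differs between these isomeric side chains.

The compounds shown leave open whether the methyl branch itself matters, as none has an unbranched chain such as 4-carboxybutyl at this position, and whether the placement of the methyl or the length of the chain up to the carboxylic acid governs the difference. Also open, from the compounds shown here alone, is how a tetrazole in place of the carboxylic acid, or a single defined stereoisomer of compound 3, would read out on half-life.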